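Methoxy for fluoro on a second indole series

The source may report more compounds than this note shows. Statements on the series, on what has been measured and on what is new or still open speak of the compounds shown alone.

Compound 1 `CC(=O)c1cc(-c2ccc(F)cc2)cc2cc(-c3ccccc3)[nH]c12` is tested in a functional assay on MCF7 cells (Homo sapiens) for cytotoxicity, read by MTT assay, with a stated time of 2 days; a lower number here means that less compound is tolerated, a higher number that more compound is tolerated. Compound 1 gives > 100000 nM, which is a limit of the assay rather than a number. Compound 2 `COc1ccc(-c2cc(C(C)=O)c3[nH]c(-c4ccccc4)cc3c2)cc1` differs by methoxy in place of fluoro on an aromatic carbon and gives 47800 nM; the change gives an at least 2.0-fold lower number from compound 1 to compound 2 (0.32 log units; beyond the scatter). Compound 3 `COc1ccc(-c2cc3cc(-c4ccc(F)cc4)cc(C(C)=O)c3[nH]2)cc1` shares the core of compound 1 except for (methoxy in place of hydrogen on an aromatic carbon). Compound 3 gives > 100000 nM, again a limit of the assay. Compound 4 `COc1ccc(-c2cc(C(C)=O)c3[nH]c(-c4ccc(OC)cc4)cc3c2)cc1` is still to be measured in this assay and differs from compound 3 by methoxy in place of fluoro on an aromatic carbon, the same change as between compound 1 and compound 2. The step is expected to be an at least 1.6-fold lower number from compound 3 to compound 4 (0.22 log units; that floor lies within the scatter), resting on an at least 2.0-fold lower number from compound 1 to compound 2 (0.32 log units; beyond the scatter), with the caution that the limit of > 100000 nM in this assay, at which 2 of the 3 values shown sit, blurs its size. Compound 4 is therefore estimated at 60000 nM, between 25000 nM and 150000 nM.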

Compound 4, concentration lethal to 50% of the cells: 25200 nM
For compound 4 the middle estimate is 2.4-fold (0.38 log units) above the measured one; low and high end bracket the measured number.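

In this assay, methoxy in place of fluoro gives an at least 3.9-fold lower number from compound 3 to compound 4 (0.59 log units; beyond the scatter), so the direction seen on the core of compound 1 also appears on the second core. Whether the size of the step carries over is a separate question, and it is not settled: the same change on two cores in this assay, an at least 2.0-fold lower number (0.32 log units; beyond the scatter) from compound 1 to compound 2 and an at least 3.9-fold lower number (0.59 log units; beyond the scatter) from compound 3 to compound 4; the limit leaves it open whether they differ. Compound 3 gives > 100000 nM, which is a limit of the assay and not a number: the limit of > 100000 nM in this assay, at which 2 of the 4 values shown sit.

A different change, methoxy in place of hydrogen on an aromatic carbon, gives a 1.9-fold lower number from compound 2 to compound 4 (0.28 log units; within the scatter), which leaves open whether that methoxy matters at all. Also open, as far as these compounds go, is whether an amine or a carboxylic acid in place of the methoxy would move the number in the same direction.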